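Moving the Pyridine Nitrogen in a Urea Pair

The source may report more compounds than this note shows. Statements on the series, on what has been measured and on what is new or still open speak of the compounds shown alone.

- compound 1 `O=C(Nc1ccc(C(=O)O)cc1)Nc1ccc(F)c(C(F)(F)F)c1` reads 1.5
- compound 2 `O=C(Nc1ccc(F)c(C(F)(F)F)c1)Nc1ccccn1` reads 3.7

In a physicochemical assay for lipophilicity, read by HPLC, measured as octanol-water partition, at pH 7.2 (on this read-out higher numbers stand for higher lipophilicity and lower numbers for lower lipophilicity), compound 2 stands higher than compound 1, by a gap beyond the usual scatter. Within the data shown here, these two are the only measured compounds so far. The next compound, compound 3 (`O=C(Nc1cccnc1)Nc1ccc(F)c(C(F)(F)F)c1`), is an isomer of compound 2: the same atoms, joined differently. The change is pyridin-3-yl in place of pyridin-2-yl on an amide-type nitrogen and, in words, pyridin-3-yl in place of pyridin-2-yl on an amide-type nitrogen. Among the measured compounds shown here, no measured pair shows this kind of swap, which leaves the expectation as a judgement. The expected step is a fall somewhat beyond the scatter (a number 0.50 log units lower from compound 2 to compound 3 (beyond the scatter)). Compound 3 is estimated at 3.2 (expected range 2.7 to 3.7).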

Compound 3, distribution coefficient: 3
Estimate against measurement, compound 3: 0.20 log units above; the measured number falls inside the stated range.
By their numbers in this assay, from the lowest: compound 1; then compound 3; then compound 2.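

In this assay, the swap of pyridin-2-yl for pyridin-3-yl on an amide-type nitrogen gives a number 0.70 log units lower from compound 2 to compound 3 (beyond the scatter) with the atoms unchanged. So at this place, where the ring nitrogen sits matters to the read-out, even though both groups count the same heavy atoms, donors and acceptors. Nothing measured here explains why the number moves.

Where pyridin-4-yl at this place would fall remains open. So does whether this step would repeat on another core, since it rests on a single pair.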